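The source may hold more compounds than are shown below. What is called first, only, known or untested is meant among the compounds shown, and "the series" means these compounds.

Working notes on the series: in an ADME assay (liver) for metabolic stability, with Liver microsome (Homo sapiens) as the target, using microsomes (a lower number here means slower removal, a higher number faster removal of the compound), compound 1 `O=c1[nH]c2ccc(-c3nnc(NCc4ccccc4)o3)cc2o1` gives 69 mL.min-1.g-1 on its own core, compound 2 `c1ccc(CNc2nnc(-c3c[nH]c4ncccc34)o2)cc1` gives 31 mL.min-1.g-1 and compound 3 `Fc1ccccc1CNc1nnc(-c2c[nH]c3ncccc23)o1` gives 32 mL.min-1.g-1 on the shared core. Compound 3 stands within the scatter of compound 2, while compound 1 carries the higher number, beyond the scatter from compound 3.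

Compound 4 `Fc1cccc(CNc2nnc(-c3c[nH]c4ncccc34)o2)c1` keeps the shared core and differs from compound 3 as follows: 3-fluorophenyl in place of 2-fluorophenyl on a saturated chain carbon bound to a nitrogen on an aromatic ring. For the measured compounds named here, no measured compound carries the 3-fluorophenyl group, so the only step that bears on this change is the fluoro in place of hydrogen on an aromatic carbon. That step, a 1.0-fold higher number from compound 2 to compound 3 (0.01 log units; within the scatter), stays within the scatter. On that basis no step beyond the scatter is expected in this assay, in either direction, and the expected change is a 1.0-fold higher number from compound 3 to compound 4 (0.01 log units; within the scatter) here. The estimate for compound 4 is 33 mL.min-1.g-1, with an expected range of 17 mL.min-1.g-1 to 62 mL.min-1.g-1 for the measurement.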

Compound 4, intrinsic clearance in microsomes: 54 mL.min-1.g-1
For compound 4 the middle estimate is 1.6-fold (0.21 log units) below the measured one; measured number inside the range.
By their numbers in this assay, from the lowest: compounds 2, 3, 4 and 1 (each within the scatter of the next, the first and the last beyond it).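

In this assay the change from 2-fluorophenyl to 3-fluorophenyl on a saturated chain carbon bound to a nitrogen on an aromatic ring gives a 1.7-fold higher number from compound 3 to compound 4 (0.23 log units; within the scatter) and so adds a second fluorophenyl group that stays within the scatter of the first. Fluoro in place of hydrogen on an aromatic carbon can now be read twice on the shared core, as a 1.0-fold higher number from compound 2 to compound 3 (0.01 log units; within the scatter) and as a 1.7-fold higher number from compound 2 to compound 4 (0.24 log units; within the scatter), and neither reading goes beyond the scatter. On these compounds, neither fluorophenyl group stands apart from the phenyl group of compound 2.

From the compounds shown here alone, it remains open whether a larger group on the phenyl ring, such as methoxy or trifluoromethyl, or a longer chain in place of the saturated chain carbon, would give a step beyond the scatter. Going by these compounds, it also remains open whether fluoro reads the same way on the core of compound 1. No measurement at hand explains the numbers in this series.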